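The compounds below may be only part of what the source reports. "The series", "measured", "known", "first", "only" and "open" are said of these compounds alone.

Measured compounds:
- compound 1, `CC(C)n1nc(-c2ccccc2)c(-c2ccccc2)cc1=O`: 152000 nM
- compound 2, `CCCCn1nc(-c2ccccc2)c(-c2ccccc2)cc1=O`: 176000 nM
- compound 3, `CCCCCCCn1nc(-c2ccccc2)c(-c2ccccc2)cc1=O`: 86000 nM

All three share one core and differ only in the chain on the aromatic nitrogen. Among the measured compounds shown here, in an assay on microsomes from liver for inhibition of sterol O-acyltransferase 1 (Rattus norvegicus) (on this read-out lower numbers stand for stronger inhibition and higher numbers for weaker inhibition), compound 3 gives the lowest number of the three, but its lead is thin: the step of a 1.8-fold lower number from compound 1 to compound 3 (0.25 log units; within the scatter) stays within the scatter, and only the step of a 2.0-fold lower number from compound 2 to compound 3 (0.31 log units; beyond the scatter) reaches beyond it, and modestly. Between the two shorter chains the step of a 1.2-fold higher number from compound 1 to compound 2 (0.06 log units; within the scatter) shows no real difference.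

Compound 4, `CCCCCCCCCn1nc(-c2ccccc2)c(-c2ccccc2)cc1=O`, has not yet been measured. It differs from compound 3 by ethyl in place of hydrogen on a saturated chain carbon, seven bonds along the chain from an aromatic nitrogen, so the chain grows again by the same kind of extension that already separates compound 2 from compound 3. For the measured compounds named here, the steps that bear on this are the two chain lengthenings just named: both pointed toward lower numbers, one within the scatter and one just beyond it. For compound 4 the expected step is therefore a small one toward a lower number, a 1.4-fold lower number from compound 3 to compound 4 (0.16 log units; within the scatter), with a fair chance that it stays within the scatter. The estimate for compound 4 in this assay is 60000 nM, with a range from 25000 nM to 150000 nM.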

Compound 4, half-maximal inhibitory concentration: 85000 nM
Compound 4: middle estimate off by 1.4-fold (0.15 log units), on the low side; measured number inside the range.
By their numbers in this assay, from the lowest: compounds 4, 3, 1 and 2 (each within the scatter of the next, the first and the last beyond it).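

Going from heptyl to nonyl adds ethyl at a place seven bonds along the chain from an aromatic nitrogen, and in this assay the step of a 1.0-fold lower number from compound 3 to compound 4 (0.01 log units; within the scatter) shows that compound 3 and compound 4 cannot be told apart. The earlier lengthening, a 2.0-fold lower number from compound 2 to compound 3 (0.31 log units; beyond the scatter) and thus just past the scatter, gave a hint that longer chains might keep lowering the number, but at these two chain lengths that hint does not carry on. Compared with the shorter chains, nonyl stands much where heptyl stood: the step of a 2.1-fold lower number from compound 2 to compound 4 (0.32 log units; beyond the scatter) is again only a modest one beyond the scatter, while the step of a 1.8-fold lower number from compound 1 to compound 4 (0.25 log units; within the scatter) stays within it, so compound 4 is separated from compound 2 but not from compound 1.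

The compounds shown leave open whether a chain longer than nonyl, or a chain ending in an amine or a carboxylic acid, would move the number any further at this nitrogen. Nothing given here offers an explanation for why the added ethyl leaves the number unmoved.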